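The source may hold more compounds than are shown below. What is called first, only, known or untested is meant among the compounds shown, and "the series" means these compounds.

Measured compounds:
compound 1, `CCCCCCCNC(=O)[C@H]1OC(n2cnc3c(N)ncnc32)[C@H](O)[C@@H]1O`, 20 nM
compound 2, `CC(C)(C)NC(=O)[C@H]1O[C@@H](n2cnc3c(N)ncnc32)[C@H](O)[C@@H]1O`, 6850 nM
compound 3, `C[C@H]1CC[C@@H](NC(=O)[C@H]2O[C@@H](n3cnc4c(N)ncnc43)[C@H](O)[C@@H]2O)CC1`, 55.6 nM

These three compounds share one core and differ only in the group on the amide-type nitrogen. In an assay on cell membranes for binding affinity to 2-oxoglutarate receptor 1 (Rattus norvegicus), read by radioligand binding (a higher number here means a weaker inhibitor, a lower number a stronger inhibitor), compound 1 gives the lowest of the three numbers; compound 3 comes nearest, and compound 2, carrying tert-butyl, lies furthest away. Within the data shown here, the one step measured on a single change, a 120-fold lower number from compound 2 to compound 3 (2.09 log units; beyond the scatter), shows that exchanging tert-butyl for a methylated six-membered ring moves the number a long way down.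

Compound 4, `CC1CCCCC1NC(=O)[C@H]1OC(n2cnc3c(N)ncnc32)[C@H](O)[C@@H]1O`, has not yet been measured in this assay. The change from compound 1 is 2-methylcyclohexyl in place of heptyl on an amide-type nitrogen. Among the measured compounds shown here, no measured pair matches this change exactly. The values of compound 1 and compound 3 show that the heptyl chain gives a lower number than the 4-methylcyclohexyl ring, while the methyl on the ring of compound 4 sits at a different position from that of compound 3, and its ring stereochemistry is not fixed. A moderately higher number than compound 1 is therefore expected, roughly in the neighbourhood of compound 3, and the estimated step is a 4.5-fold higher number from compound 1 to compound 4 (0.65 log units; beyond the scatter). The estimated value for compound 4 is 90 nM, with a range from 25 nM to 400 nM.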

Compound 4, inhibition constant: 69.5 nM
The estimate for compound 4 lay 1.3-fold (0.11 log units) above the measured number, within the range that was stated.
By their numbers in this assay, from the lowest: compound 1; then compounds 3 and 4 (each within the scatter of the next); then compound 2.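

In this assay, replacing the open heptyl chain with the 2-methylcyclohexyl ring gives a 3.5-fold higher number from compound 1 to compound 4 (0.54 log units; beyond the scatter) on the amide-type nitrogen, even though both groups hold 7 carbon atoms and neither adds a hydrogen-bond donor, acceptor or charge. Among these compounds, this is the first direct comparison of a chain and a ring here, and the modest step is much smaller than a 120-fold lower number from compound 2 to compound 3 (2.09 log units; beyond the scatter) in this assay, so a ring at this place can keep the number fairly close to that of the heptyl compound. Compound 3 and compound 4 lie within the scatter of each other, so these values do not separate 4-methylcyclohexyl from 2-methylcyclohexyl, and no measured evidence explains the step from chain to ring.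

As far as these compounds go, the structure of compound 4 does not fix the ring stereochemistry, so it remains open how each arrangement of the 2-methylcyclohexyl group would read. The compounds shown also leave open how a plain cyclohexyl ring, a chain longer than heptyl or a chain ending in an amine or a carboxylic acid would behave at this place.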